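Extending the acrylamide of compound 1 with a piperidine-bearing chain

The source may report more compounds than this note shows. Statements on the series, on what has been measured and on what is new or still open speak of the compounds shown alone.

Measured compounds:
compound 1, `C=CC(=O)Nc1cc2c(N3CCc4ccccc43)ncnc2cc1OC`, 11700 nM
compound 2, `C/C=C/C(=O)Nc1cc2c(N3CCCc4ccccc43)ncnc2cc1OC`, 12700 nM
compound 3, `CC(C)=CC(=O)Nc1cc2c(N3CCCc4ccccc43)ncnc2cc1O[C@@H]1CCOC1`, 11100 nM

All three were tested in a functional assay on MCF7 cells (Homo sapiens) for antiproliferative activity, read by MTT assay, with a stated time of 72 h; on this read-out lower numbers stand for stronger inhibition and higher numbers for weaker inhibition. Compound 1 stands second highest of the three numbers, yet its gaps to compound 3 and to compound 2 both lie within the scatter, so the three cannot be ordered. Compound 4, `COc1cc2ncnc(N3CCc4ccccc43)c2cc1NC(=O)/C=C/CN1CCCCC1`, has not yet been measured in this assay. It differs from compound 1 at one spot: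

3-(piperidin-1-yl)prop-1-en-1-yl in place of vinyl on a carbonyl carbon

Going by the values given here, no pair of measured compounds shows what a change at this place does, so there is no measured step to lean on. Given that compound 1, compound 2 and compound 3 all sit close together, the expected step of a 1.5-fold lower number from compound 1 to compound 4 (0.17 log units; within the scatter) is modest and only tentatively toward a lower number. Compound 4 is therefore estimated at 8000 nM, within 2500 nM to 25000 nM.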

Compound 4, half-maximal inhibitory concentration: 1680 nM
Estimate against measurement, compound 4: 4.8-fold (0.68 log units) above; measured number outside the range, below it.
By their numbers in this assay, from the lowest: compound 4; then compounds 3, 1 and 2 (each within the scatter of the next).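

In this assay, putting 3-(piperidin-1-yl)prop-1-en-1-yl in place of vinyl on the carbonyl carbon gives a 7.0-fold lower number from compound 1 to compound 4 (0.84 log units; beyond the scatter) and so shows that this place accepts a much larger group with a number that falls beyond the scatter. Going by these compounds alone, it is also the first single change here with a readable effect. No measured evidence explains the step. As far as these compounds go, the change brings in the longer chain and the piperidine ring together, so their separate shares remain open. From the compounds shown here alone, whether a morpholine or a dimethylamino group in place of the piperidine would give a similar number also remains open.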